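Branching the Chain Next to the Carbamate Oxygen

The source may hold more compounds than are shown below. What is called first, only, known or untested is meant among the compounds shown, and "the series" means these compounds.

Measured so far in an assay on microsomes from intestine for inhibition of acyl-CoA:cholesterol acyltransferase (Oryctolagus cuniculus); on this read-out lower numbers stand for stronger inhibition and higher numbers for weaker inhibition:
- compound 1 `CCCCCCCCCCCCOC(=O)NC(=O)Oc1c(C(C)C)cccc1C(C)C`: 21 nM
- compound 2 `CCCCCCCCCCCCCOC(=O)NC(=O)Oc1c(C(C)C)cccc1C(C)C`: 9 nM
- compound 3 `CCCCCCCCCCCCCCOC(=O)NC(=O)Oc1c(C(C)C)cccc1C(C)C`: 10 nM

Compound 2 gives the lowest of the three numbers. Its nearest neighbour is compound 3, from which it differs only within the usual scatter, so the two cannot be ordered; compound 1 sits clearly further off, as a 2.3-fold lower number from compound 1 to compound 2 (0.37 log units; beyond the scatter) shows.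

Compound 4 `CCCCCCCCCCCCC(C)OC(=O)NC(=O)Oc1c(C(C)C)cccc1C(C)C` differs from compound 2 by methyl in place of hydrogen on a saturated chain carbon bound to an oxygen next to a carbonyl group and a saturated chain carbon. The measured steps all concern the far end of the chain: a 2.3-fold lower number from compound 1 to compound 2 (0.37 log units; beyond the scatter) and a 2.1-fold lower number from compound 1 to compound 3 (0.32 log units; beyond the scatter) were modest, while a 1.1-fold higher number from compound 2 to compound 3 (0.05 log units; within the scatter) stayed within the scatter. None of them touches the carbon bound to the oxygen, so they bear on the new change only by showing that one added carbon somewhere along the chain has given modest or no shifts. A step within the scatter, or a small rise, is therefore expected in this assay, as a 1.4-fold higher number from compound 2 to compound 4 (0.16 log units; within the scatter).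

Compound 4 is thus estimated at 13 nM, with a range from 4 nM to 40 nM.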

Compound 4, half-maximal inhibitory concentration: 17 nM
Estimate against measurement, compound 4: 1.3-fold (0.12 log units) below; the measured number falls inside the stated range.
By their numbers in this assay, from the lowest: compounds 2, 3, 4 and 1 (each within the scatter of the next, the first and the last beyond it).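

This is the first change shown on the saturated chain carbon bound to the oxygen next to a carbonyl group, as the earlier steps all lay at the far end of the chain. In this assay the methyl gives a 1.9-fold higher number from compound 2 to compound 4 (0.28 log units; within the scatter) and this stays within the scatter, so compound 2 and compound 4 cannot be ordered and this carbon accepts a methyl without a step beyond the scatter. Nothing shown here offers an explanation for this result.

A single methyl says little about larger groups, so an ethyl or a phenyl group on this same carbon, or a second methyl on it, remains an open case. As far as these compounds go, whether an amine or a hydroxyl group at this carbon would be accepted is equally open.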